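Cyclopentyl Replaces Fluorophenyl on the Amide Carbonyl

A few compounds are considered here, and "the series" means these few. Any claim that something is new, unique, unknown or untested is made for them only; others in the source may bear on it.

The three measured compounds share one core and differ only in the group on the carbonyl carbon. Compound 3 `CC(C)[C@@H](NC(=O)c1ccc(F)cc1)C(=O)N1CCC(c2ccc(Cl)cc2)CC1` in an assay on THP-1 cells for displacement of a labelled ligand from C-C chemokine receptor type 1 (Homo sapiens) (on this read-out lower numbers stand for stronger inhibition and higher numbers for weaker inhibition), gives 118 nM, the second highest of the three numbers in hand. Its nearest neighbour is compound 2 `CC(C)[C@@H](NC(=O)Nc1ccccc1)C(=O)N1CCC(c2ccc(Cl)cc2)CC1`, which in this assay gives 616 nM, and the furthest is compound 1 `Cc1ccccc1CCC(=O)N[C@@H](C(=O)N1CCC(c2ccc(Cl)cc2)CC1)C(C)C`, which in this assay gives 19 nM. The steps of a 6.2-fold higher number from compound 1 to compound 3 (0.79 log units; beyond the scatter) and a 5.2-fold lower number from compound 2 to compound 3 (0.72 log units; beyond the scatter) both bear on changes at this carbonyl carbon, while a 32-fold higher number from compound 1 to compound 2 (1.51 log units; beyond the scatter) is the widest spread seen.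

Compound 4 `CC(C)[C@@H](NC(=O)C1CCCC1)C(=O)N1CCC(c2ccc(Cl)cc2)CC1` is not yet measured. The change from compound 3 to compound 4 is cyclopentyl in place of 4-fluorophenyl on a carbonyl carbon. Among the compounds with values here, no measured step exchanges an aromatic ring for a non-aromatic one at this position, so the direction is uncertain, and the analyst expects at most a modest step, a 1.7-fold higher number from compound 3 to compound 4 (0.23 log units; within the scatter), in this assay. The analyst's estimate for compound 4 in this assay is 200 nM, with a range from 60 nM to 700 nM.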

Compound 4, half-maximal inhibitory concentration: 70 nM
For compound 4 the middle estimate is 2.9-fold (0.46 log units) above the measured one; the measured number falls inside the stated range.
By their numbers in this assay, from the lowest: compound 1; then compounds 4 and 3 (each within the scatter of the next); then compound 2.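

In this assay this is the first exchange of an aromatic ring for a non-aromatic one on this carbonyl carbon, and a 1.7-fold lower number from compound 3 to compound 4 (0.23 log units; within the scatter) places the two compounds within the scatter of each other, so among these compounds the 4-fluorophenyl ring is not needed for a number in this range. The same cyclopentyl group stands clearly apart from the anilino group, with an 8.8-fold lower number from compound 2 to compound 4 (0.94 log units; beyond the scatter), yet does not match the 2-(2-methylphenyl)ethyl group, with a 3.7-fold higher number from compound 1 to compound 4 (0.57 log units; beyond the scatter), which leaves compound 1 with the lowest number of the four. Nothing in the data at hand accounts for this order.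

Still open, as far as these compounds go, is whether the lower number of compound 1 belongs to its chain or to its ring, which a 2-cyclopentylethyl group on the carbonyl carbon would help to separate. Also open, from the compounds shown here alone, is how a cyclopentyl ring carrying an amine or a carboxylic acid would read at this place.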